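Chlorophenyl position and kinetic solubility across two cores

The source may report more compounds than this note shows. Statements on the series, on what has been measured and on what is new or still open speak of the compounds shown alone.

Compound 1 `CNC(=O)c1cc(C(=O)N[C@H]2CC[C@H](O)CC2)n([C@@H](C)c2ccc(Cl)cc2)n1` — in a physicochemical assay for solubility, measured as kinetic solubility (a lower number here means a less soluble compound, a higher number a more soluble compound), compound 1 gives >= 132 ug/mL, a limit of the assay.
Compound 3 `CNC(=O)c1cc(C(=O)N[C@H]2CC[C@H](O)CC2)n([C@@H](C)c2ccccc2Cl)n1` — in this assay compound 3 gives >= 182 ug/mL, also a limit.
Compound 2 `CNC(=O)c1cc(C(=O)N[C@H]2CC[C@H](O)CC2)c([C@@H](C)c2ccccc2Cl)o1` — in this assay compound 2 gives >= 242 ug/mL, again a limit.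

The step that the two limits leave unreadable from compound 3 to compound 1 is made by 4-chlorophenyl in place of 2-chlorophenyl on a saturated chain carbon bound to an aromatic nitrogen and a saturated chain carbon; with both ends at a limit its size cannot be read. Compound 4 `CNC(=O)c1cc(C(=O)N[C@H]2CC[C@H](O)CC2)c([C@@H](C)c2ccc(Cl)cc2)o1` is not yet measured and differs from compound 2 by 4-chlorophenyl in place of 2-chlorophenyl on a saturated chain carbon bound to an aromatic carbon and a saturated chain carbon. The difference between the cores of compound 2 and compound 3 is not broken down here. Around the place, compound 3 has the chain carbon bound to an aromatic nitrogen, compound 2 to an aromatic carbon, so the change is the same kind of change, not the same. The expected step is a number no higher from compound 2 to compound 4 (the limit leaves the size open), resting on compound 2 sitting at the limit >= 242 ug/mL. Compound 4 is estimated at 240 ug/mL, most likely reported again as a limit.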

Compound 4, solubility: >= 118 ug/mL
Compound 4: no number, only a limit; the forecaster's own chance of this, stated with the estimate: 75%; the middle value is on the limit's open side.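

In this assay, among the compounds shown here, compound 2 and compound 4 both stand at limits of the assay, so no step between them can be read. The compounds shown leave open whether 4-chlorophenyl in place of 2-chlorophenyl changes the reading on either core, as all four values are limits.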